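The compounds below may be only part of what the source reports. "The series", "measured", "known", "first", "only" and "open" are said of these compounds alone.

Measured compounds:
compound 1, `O=C1CCC(CCN2CC(N3CCNCC3)C2)(c2ccc(Cl)c(Cl)c2)CN1CC1CC1`, 12.6 nM
compound 2, `CS(=O)(=O)N1CCN(C2CN(CCC3(c4ccc(Cl)c(Cl)c4)CCC(=O)N(CC4CC4)C3)C2)CC1`, 3.16 nM
compound 3, `CNS(=O)(=O)N1CCN(C2CN(CCC3(c4ccc(Cl)c(Cl)c4)CCC(=O)N(CC4CC4)C3)C2)CC1`, 3.16 nM

In an assay on isolated protein (artery, Oryctolagus cuniculus) with Substance-P receptor (Homo sapiens) as the target (a lower number here means tighter binding, a higher number weaker binding), compound 3 sits level with compound 2, the two together giving the lowest numbers, while compound 1 is set apart by a 4.0-fold lower number from compound 1 to compound 3 (0.60 log units; beyond the scatter). Compound 4, `NC1CCN(C2CN(CCC3(c4ccc(Cl)c(Cl)c4)CCC(=O)N(CC4CC4)C3)C2)CC1`, carries 4-aminopiperidin-1-yl in place of 4-(methylsulfamoyl)piperazin-1-yl on a saturated ring carbon. Among the measured compounds shown here, the step that bears on this is the one from compound 1 to compound 3, where adding the methylsulfamoyl group gave a 4.0-fold lower number from compound 1 to compound 3 (0.60 log units; beyond the scatter); compound 4 again lacks any sulfonyl group, and also swaps the ring nitrogen bearing it for a ring carbon bearing an amino group. A modest weakening, back toward the level of compound 1, is therefore expected, estimated as a 3.2-fold higher number from compound 3 to compound 4 (0.50 log units; beyond the scatter). For compound 4 the expected value in this assay is 10 nM, within 3 nM to 40 nM.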

Compound 4, dissociation constant: 2 nM
Compound 4: middle estimate off by 5.0-fold (0.70 log units), on the high side; measured number below the stated range.
By their numbers in this assay, from the lowest: compounds 4, 2 and 3 (each within the scatter of the next); then compound 1.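

In this assay a sulfonyl group proves unnecessary at this position: a 1.6-fold lower number from compound 3 to compound 4 (0.20 log units; within the scatter) and a 1.6-fold lower number from compound 2 to compound 4 (0.20 log units; within the scatter) put 4-aminopiperidin-1-yl, which carries no sulfur, on a level with both sulfonyl-bearing piperazines. Among the compounds shown here, with a 6.3-fold lower number from compound 1 to compound 4 (0.80 log units; beyond the scatter) on record, a sulfonyl group is no longer the only change that separates a compound from compound 1. Nothing available explains why this amine does as well.

On these data alone, whether the amino group on the piperidine ring matters stays open. An acetamide or a dimethylamino group in its place would test that.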